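This account rests on a few compounds, and the source may have more. Where it says the series, first, only, none or still open, it means among the compounds named here.

Working notes on the series. Among the measured compounds shown here, compound 3 `N#Cc1cc(-c2ccccc2)c2ccc(OCc3cccc(C4(O)CCOCC4)c3)cc2c1` gives 120 nM in an assay on isolated protein with Polyunsaturated fatty acid 5-lipoxygenase (Homo sapiens) as the target (a lower number here means a stronger inhibitor, a higher number a weaker inhibitor), the lowest of the three numbers so far. Compound 1 `COCc1cc(-c2ccccc2)c2ccc(OCc3cccc(C4(O)CCOCC4)c3)cc2c1` gives 160 nM and compound 2 `COC(C)c1cc(-c2ccccc2)c2ccc(OCc3cccc(C4(O)CCOCC4)c3)cc2c1` gives 1200 nM; the step of a 1.3-fold lower number from compound 1 to compound 3 (0.12 log units; within the scatter) lies within the scatter, so compound 3 and compound 1 are not separable, while a 10-fold lower number from compound 2 to compound 3 (1.00 log units; beyond the scatter) and a 7.5-fold higher number from compound 1 to compound 2 (0.88 log units; beyond the scatter) are beyond it.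

Compound 4 `Cn1nnnc1-c1cc(-c2ccccc2)c2ccc(OCc3cccc(C4(O)CCOCC4)c3)cc2c1` has not been measured. The change is 1-methyl-1H-tetrazol-5-yl in place of cyano on an aromatic carbon: the entering group is a 1-methyl-1H-tetrazol-5-yl, six heavy atoms in a five-membered aromatic ring with four hetero atoms, replacing the two-atom cyano.

For the measured compounds named here, the steps that bear on this position are a 1.3-fold lower number from compound 1 to compound 3 (0.12 log units; within the scatter), small, and a 10-fold lower number from compound 2 to compound 3 (1.00 log units; beyond the scatter), modest. Cyano and methoxymethyl are interchangeable at this carbon; the larger 1-methoxyethyl cost a modest step. The tetrazole is larger still than anything measured here, so a modest rise beyond the scatter is expected rather than none, with wide uncertainty because only compound 2 1200 nM samples a bulkier group.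

Compound 4 is expected at 400 nM, in the range 150 nM to 1200 nM. The expected step is a 3.3-fold higher number from compound 3 to compound 4 (0.52 log units; beyond the scatter).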

Compound 4, half-maximal inhibitory concentration: 3000 nM
Compound 4: middle estimate off by 7.5-fold (0.88 log units), on the low side; measured number outside the range, above it.
By their numbers in this assay, from the lowest: compounds 3 and 1 (each within the scatter of the next); then compound 2; then compound 4.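

In this assay, this aromatic carbon is shown to be far less open to change than the earlier compounds suggested: the 1-methyl-1H-tetrazol-5-yl group brings a 25-fold higher number from compound 3 to compound 4 (1.40 log units; beyond the scatter) and a 19-fold higher number from compound 1 to compound 4 (1.27 log units; beyond the scatter), both large steps. It also goes past the one earlier loss at this carbon, with a 2.5-fold higher number from compound 2 to compound 4 (0.40 log units; beyond the scatter), so 1-methoxyethyl no longer marks the upper end of the series. This is also the first ring sampled at this carbon, and the first case in which a group of six heavy atoms in a five-membered aromatic ring replaces an open-chain group, and the result is the highest number of the four, with compound 3 at 120 nM and compound 1 at 160 nM remaining the best-placed pair. What lies behind this loss has no support in the data at hand.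

The four compounds cannot separate the effect of the ring itself from that of its methyl group or its ring nitrogens, and a single ring cannot speak for rings in general, so an unsubstituted tetrazole, a furan or a pyridine would be needed to tell these apart. Going by these compounds, whether any group here can go below compound 3 and compound 1 also stays open, for example a primary amide, a carboxylic acid or a short amine chain.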